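A Larger Group on the Aromatic Nitrogen

This account rests on a few compounds, and the source may have more. Where it says the series, first, only, none or still open, it means among the compounds named here.

In an ADME assay on Vero cells (Chlorocebus sabaeus) for cytotoxicity, read by neutral red uptake, with a stated time of 3 days (a higher number here means that more compound is tolerated, a lower number that less compound is tolerated), compound 1 `CCn1ncc2c(C(=O)NCCN(C)C)cc(C3CC3)nc21` gives > 300000 nM, which is a limit of the assay and not a number. Compound 2 `Cc1cc(C(=O)NCCN(C)C)c2c(C)nn(C(C)(C)C)c2n1` gives 184000 nM. Compound 3 `CCCn1ncc2c(C(=O)NCCN(C)C)cc(C3CC3)nc21` gives 111000 nM, within the scatter of compound 2. Compound 4 `CC(C1CC1)n1ncc2c(C(=O)NCCN(C)C)cc(C3CC3)nc21` carries 1-cyclopropylethyl in place of propyl on an aromatic nitrogen. For the measured compounds named here, only one measured step bears on this change: methyl in place of hydrogen on a saturated chain carbon, which gave an at least 2.7-fold lower number from compound 1 to compound 3 (0.43 log units; beyond the scatter), beyond the scatter. On that single step, a further move toward a lower number seems likely, though its size is uncertain. The expected change is a 1.9-fold lower number from compound 3 to compound 4 (0.27 log units; within the scatter). For compound 4 the estimated value is 60000 nM, with an expected range from 20000 nM to 150000 nM.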

Compound 4, half-maximal cytotoxic concentration: 51700 nM
Compound 4: middle estimate off by 1.2-fold (0.06 log units), on the high side, and the stated range covers the measured number.
By their numbers in this assay, from the lowest: compound 4; then compounds 3 and 2 (each within the scatter of the next). At a limit, above all of these: compound 1.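

In this assay, 1-cyclopropylethyl in place of propyl on the aromatic nitrogen gives a 2.1-fold lower number from compound 3 to compound 4 (0.33 log units; beyond the scatter), so this position responds beyond the scatter to a larger group holding a ring, not only to an added methyl. The whole distance along this series is an at least 5.8-fold lower number from compound 1 to compound 4 (0.76 log units; beyond the scatter). Compound 1 gives > 300000 nM, which is a limit of the assay and not a number, so that larger step is only a bound.

From the compounds shown here alone, whether a longer open chain such as butyl would match the ring-bearing group remains open. So does the effect of an amine or a carboxylic acid at this position.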